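The source may hold more compounds than are shown below. What is called first, only, known or untested is meant among the compounds shown, and "the series" means these compounds.

Measured in a functional assay on RAW264.7 cells (Mus musculus) for inhibition, read by ELISA, with a stated time of 24 h (a higher number here means that more compound is needed for the effect, a lower number that less compound is needed), so far:
- compound 1 `CC/C=C\C[C@H]1C(=O)C=C[C@H]1CC(=O)OCCCCC` gives 25000 nM
- compound 2 `CC/C=C\C[C@H]1C(=O)C=C[C@H]1CC(=O)OCc1ccccc1` gives 20000 nM
- compound 3 `CC/C=C\C[C@H]1C(=O)C=C[C@H]1CC(=O)Oc1ccc(O)cc1` gives 23000 nM

Compound 1 stands level with the other two compounds, as no gap among the three goes beyond the scatter. The next compound is compound 4 `CC/C=C\C[C@H]1C(=O)C=C[C@H]1CC(=O)OC(C)C`, which keeps the core of compound 1 and carries isopropyl in place of pentyl on an oxygen next to a carbonyl group as its only difference. The measured steps at this group are a 1.3-fold lower number from compound 1 to compound 2 (0.10 log units; within the scatter), a 1.1-fold lower number from compound 1 to compound 3 (0.04 log units; within the scatter) and a 1.2-fold higher number from compound 2 to compound 3 (0.06 log units; within the scatter), and none of them leaves the scatter. Within the data shown here, no measured compound carries isopropyl, so this is a reading across from pentyl, benzyl and 4-hydroxyphenyl on that oxygen. No step beyond the scatter is therefore expected in this assay. The estimated change is a 1.0-fold lower number from compound 1 to compound 4 (0.02 log units; within the scatter) and is expected to be no real change. Compound 4 is expected at 24000 nM, with an estimated range from 12000 nM to 45000 nM.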

Compound 4, half-maximal effective concentration: 20000 nM
Compound 4: middle estimate off by 1.2-fold (0.08 log units), on the high side; the measured number falls inside the stated range.
By their numbers in this assay, from the lowest: compounds 2, 4, 3 and 1 (each within the scatter of the next).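

In this assay, isopropyl on an oxygen next to a carbonyl group stays level with the three groups seen earlier at this position (a 1.3-fold lower number from compound 1 to compound 4 (0.10 log units; within the scatter); a 1.2-fold lower number from compound 3 to compound 4 (0.06 log units; within the scatter); no change at the digits printed from compound 2 to compound 4 (within the scatter)). The level reading now extends from pentyl, with 5 heavy atoms, down to isopropyl, with 3 heavy atoms, and none of the four compounds goes against it. Nothing measured here explains this flat response at the position.

Going by these compounds, whether a longer chain such as decyl, a chain ending in an amine or in a carboxylic acid, or a hydrogen in place of the whole group on this oxygen would stay level remains open. With every step so far inside the scatter, the compounds shown also leave open which change at this position, if any, would move the number in this series.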